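This account rests on a few compounds, and the source may have more. Where it says the series, first, only, none or still open, it means among the compounds named here.

Two compounds in this set have a number in an assay on cells for inhibition of endothelial lipase (Homo sapiens), read by LC-MS, with stated times of 10 min and 30 min; on this read-out higher numbers stand for weaker inhibition and lower numbers for stronger inhibition. Compound 1 `O=C(N[C@H]1CC[C@@H](c2ccccc2)CC1)c1[nH]c(=O)[nH]c(=O)c1NC1CCCC1` gives 156 nM in this assay. Compound 2 `O=C(N[C@H]1CC[C@@H](c2ccccc2)CC1)c1[nH]c(=O)[nH]c(=O)c1O` gives 26 nM in this assay, the lowest of the two numbers, and its nearest neighbour is compound 1. Within the data shown here, the only measured step, a 6.0-fold lower number from compound 1 to compound 2 (0.78 log units; beyond the scatter), comes from putting hydroxy in place of cyclopentylamino on an aromatic carbon; it lies beyond the scatter and is modest in size.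

Compound 3 `CC(C)Cn1c(=O)[nH]c(C(=O)N[C@H]2CC[C@@H](c3ccccc3)CC2)c(O)c1=O` has not yet been measured. It differs from compound 2 by isobutyl in place of hydrogen on an aromatic nitrogen: a hydrogen leaves and an isobutyl group enters on an aromatic nitrogen of a six-membered aromatic ring with two nitrogen, ortho to two groups of one heavy atom each, meta to a hydroxy group, para to a large group. Among the measured compounds shown here, the single measured step concerns a different place on the shared core, so no measured step bears directly on this change, and the data give no direction. The expected step of a 1.5-fold higher number from compound 2 to compound 3 (0.19 log units; within the scatter) is therefore none beyond the scatter. For compound 3 the estimate in this assay is 40 nM, with a range from 10 nM to 160 nM.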

Compound 3, half-maximal inhibitory concentration: 59 nM
Estimate against measurement, compound 3: 1.5-fold (0.17 log units) below; measured number inside the range.
By their numbers in this assay, from the lowest: compound 2; then compound 3; then compound 1.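

Among these compounds, until now the only measured change sat at a different place on the shared core, so compound 3 gives the first reading at this aromatic nitrogen. In this assay, isobutyl in place of hydrogen brings a 2.3-fold higher number from compound 2 to compound 3 (0.36 log units; beyond the scatter) and this modest loss of inhibition shows that the position is not indifferent to the change, yet compound 3 still gives 59 nM in this measurement, so a substituent on this nitrogen does not abolish inhibition. No measurement shown here explains why the number rises.

On these data alone, one group gives only one point, so it remains open whether the rise belongs to isobutyl itself or to any substituent on this nitrogen; a methyl group, a longer chain, or a chain ending in an amine or a carboxylic acid at the same place would help separate these possibilities. Also open, as far as these compounds go, is whether isobutyl would bring a similar step in a compound carrying cyclopentylamino in place of the hydroxy group.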